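Bromo placement across the two indoles of the series

The source may hold more compounds than are shown below. What is called first, only, known or untested is meant among the compounds shown, and "the series" means these compounds.

Compound 2 `O=C(C1=NC(c2c[nH]c3ccccc23)CN1)c1c[nH]c2cc(Br)ccc12` is the reference for this step. In an ADME assay on SK-OV-3 cells (Homo sapiens) for cytotoxicity (a higher number here means that more compound is needed for the effect, a lower number that less compound is needed), compound 2 gives > 30 ug/mL, which is a limit of the assay rather than a number. Compound 1 `O=C(C1=NC(c2c[nH]c3cc(Br)ccc23)CN1)c1c[nH]c2ccccc12` carries its bromo on the other indole and in this assay compound 1 gives 3.71 ug/mL. Among the measured compounds shown here, no step between measured compounds is counted here; the only evidence on the measured values is the limit of > 30 ug/mL in this assay, at which 1 of the 2 values shown sits, so where compound 2 stands on the numbers is known only as this limit.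

Compound 3 `O=C(C1=NC(c2c[nH]c3cc(Br)ccc23)CN1)c1c[nH]c2cc(Br)ccc12` differs from compound 2 by bromo in place of hydrogen on an aromatic carbon, so it carries bromo on both indoles. The expected step of an at least 3.0-fold lower number from compound 2 to compound 3 (0.47 log units; beyond the scatter) in this assay is an estimate toward lower values, of a size beyond the usual scatter, since compound 1, which shares the entering bromo, gives 3.71 ug/mL. For compound 3 the estimate in this assay is 10 ug/mL, with a range from 3 ug/mL to 30 ug/mL.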

Compound 3, concentration for half-maximal effect: 4.81 ug/mL
Compound 3: middle estimate off by 2.1-fold (0.32 log units), on the high side; measured number inside the range.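

In this assay, the bromo that compound 1 carries keeps its place in the result when the bromo of compound 2 is also present, with an at least 6.2-fold lower number from compound 2 to compound 3 (0.79 log units; beyond the scatter). The reverse addition gives no separation from the scatter, with a 1.3-fold higher number from compound 1 to compound 3 (0.11 log units; within the scatter), so in this pair a second bromo on an aromatic carbon of the other indole brings no gain and no loss. The first step is only a bound, not a measured size, since compound 2 stands at a limit of the assay: the limit of > 30 ug/mL in this assay, at which 1 of the 3 values shown sits.

On these data alone, whether chloro, methoxy or an amine could stand in place of the bromo on the indole that decides the result stays open. As far as these compounds go, the actual number for compound 2 also stays open, so the full size of the first step cannot be given.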